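The source may report more compounds than this note shows. Statements on the series, on what has been measured and on what is new or still open speak of the compounds shown alone.

Working notes on the series. Within the data shown here, in an assay on CHO cells for displacement of a labelled ligand from muscarinic acetylcholine receptor M5 (Homo sapiens), read by scintillation counting, with a stated time of 2 h (a lower number here means a stronger inhibitor, a higher number a weaker inhibitor), compound 1 `O=C(OCCc1ccc(Cl)c(Cl)c1)N(c1ccccc1)C1CN2CCC1CC2` gives 80 nM, and compound 2 `COc1ccc(CCOC(=O)N(c2ccccc2)C2CN3CCC2CC3)cc1` gives 230 nM; compound 2 therefore stands at the higher of the two numbers, with a 2.9-fold higher number from compound 1 to compound 2 (0.46 log units; beyond the scatter) as the only step measured so far. Compound 3 `O=C(OCc1ccc(Cl)c(Cl)c1)N(c1ccccc1)C1CN2CCC1CC2` has not been measured in this assay. It differs from compound 2 by 3,4-dichlorophenyl in place of 4-methoxybenzyl on a saturated chain carbon bound to an oxygen next to a carbonyl group. Among the measured compounds shown here, the measured step bears on it only in part: it reverses the aryl exchange of a 2.9-fold higher number from compound 1 to compound 2 (0.46 log units; beyond the scatter), but in compound 3 the ring sits directly on the carbon bound to the oxygen, whereas in compound 1 it sits two bonds along the chain; no measured pair shows what that shift does. The expectation is a step of about a 2.3-fold lower number from compound 2 to compound 3 (0.36 log units; beyond the scatter) in this assay, a lower number, its size uncertain. Compound 3 is therefore estimated at 100 nM, within 30 nM to 400 nM.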

Compound 3, inhibition constant: 60 nM
The estimate for compound 3 lay 1.7-fold (0.22 log units) above the measured number, and the stated range covers the measured number.
By their numbers in this assay, from the lowest: compounds 3 and 1 (each within the scatter of the next); then compound 2.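

In this assay, 3,4-dichlorophenyl in place of 3,4-dichlorobenzyl on a saturated chain carbon bound to an oxygen next to a carbonyl group gives a 1.3-fold lower number from compound 1 to compound 3 (0.12 log units; within the scatter), so the difference in chain length between these two compounds does not separate them in this read-out. At the same place, the exchange against 4-methoxybenzyl gives a 3.8-fold lower number from compound 2 to compound 3 (0.58 log units; beyond the scatter), which sets compound 2 apart from compound 3 by more than the scatter, while the two dichloro compounds stay together. Nothing at hand explains either step.

Still open, going by these compounds, is whether an unsubstituted phenyl or a single chlorine on the ring would fall with compound 3 or with compound 2. Also open, on these data alone, is whether a longer chain, or an amine on that chain, would leave the number as unaffected as the present chain difference does.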